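The compounds below may be only part of what the source reports. "The series", "measured", "known", "first", "only" and "open" are said of these compounds alone.

Measured so far in a functional assay on CHO cells for antagonist activity at prostaglandin E2 receptor EP1 subtype (Homo sapiens), read by FLIPR and calcium flux; on this read-out lower numbers stand for stronger inhibition and higher numbers for weaker inhibition:
- compound 1 `CCOc1ccc(Cc2nnc(CN(c3cccc(Cl)c3C)S(=O)(=O)c3ccc(C)cc3)o2)cc1`: 50.1 nM
- compound 2 `Cc1ccc(S(=O)(=O)N(Cc2nnc(Cc3ccc(F)cc3)o2)c2cccc(Cl)c2C)cc1`: 501 nM
- compound 3 `Cc1ccc(S(=O)(=O)N(Cc2nnc(Cc3ccccc3Cl)o2)c2cccc(Cl)c2C)cc1`: 398 nM

Compound 3 stands second highest of the three numbers. Its nearest neighbour is compound 2, at a 1.3-fold lower number from compound 2 to compound 3 (0.10 log units; within the scatter), a gap within the scatter; its furthest is compound 1, at a 7.9-fold higher number from compound 1 to compound 3 (0.90 log units; beyond the scatter), beyond the scatter. Compound 1 is also set apart from compound 2 by a 10-fold higher number from compound 1 to compound 2 (1.00 log units; beyond the scatter).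

Compound 4 `Cc1ccc(S(=O)(=O)N(Cc2nnc(Cc3ccc(Cl)cc3Cl)o2)c2cccc(Cl)c2C)cc1` has not been measured. It differs from compound 3 in one place: chloro in place of hydrogen on an aromatic carbon Cut one bond further out, this reads 2-chlorophenyl to 2,4-dichlorophenyl, or 2-chlorobenzyl to 2,4-dichlorobenzyl.

Among the compounds with values here, no measured step adds a chloro to this benzyl ring, so the bearing of the known steps is indirect. Within the data shown here, the only step that changes this ring without touching the rest of the molecule, from compound 2 to compound 3, is a 1.3-fold lower number from compound 2 to compound 3 (0.10 log units; within the scatter), within the scatter, while the exchange of the 4-ethoxyphenyl of compound 1 for a smaller substituted phenyl costs a 7.9-fold higher number from compound 1 to compound 3 (0.90 log units; beyond the scatter). A second chloro on an already modest compound is therefore expected to move the number in this assay little, as a 1.1-fold lower number from compound 3 to compound 4 (0.06 log units; within the scatter), not beyond the scatter. Compound 4 is estimated at 350 nM, within 120 nM to 1000 nM.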

Compound 4, inhibition constant: 1000 nM
Estimate against measurement, compound 4: 2.9-fold (0.46 log units) below; the measured number falls inside the stated range.
By their numbers in this assay, from the lowest: compound 1; then compounds 3, 2 and 4 (each within the scatter of the next, the first and the last beyond it).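

Adding a chloro para to a large group and meta to the existing chloro group is not neutral on this ring in this assay (a 2.5-fold higher number from compound 3 to compound 4 (0.40 log units; beyond the scatter)), the first change among the halogen-bearing benzyl compounds to lie beyond the scatter, and it shows that this position responds even though the change from 4-fluorophenyl to 2-chlorophenyl did not. The 2,4-dichlorophenyl compound still sits within the scatter of the 4-fluorophenyl compound (a 2.0-fold higher number from compound 2 to compound 4 (0.30 log units; within the scatter)), while the gap to the 4-ethoxyphenyl compound now widens to a large one (a 20-fold higher number from compound 1 to compound 4 (1.30 log units; beyond the scatter)), so a substituent at this ring position does not by itself bring the lower numbers seen with ethoxy. Nothing at hand accounts for the effect of the added chloro.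

Open, from the compounds shown here alone, is whether a lone 4-chlorophenyl would behave like the 2,4-dichlorophenyl ring, or whether the higher number needs both chloro groups together. Also open, going by these compounds, is how far the ethoxy result extends at this position, for instance to methoxy, a longer alkoxy chain or a dimethylamino group.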